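Fluoro on the Phenoxy Ring: What Compound 3 May Show

The source may report more compounds than this note shows. Statements on the series, on what has been measured and on what is new or still open speak of the compounds shown alone.

Measured so far:
Compound 1, `Cn1ccc2c(Oc3ccc(NC(=O)c4nn(-c5ccc(Br)cc5)ccc4=O)cc3)ccnc21`, in a functional assay on A549 cells (Homo sapiens) for cytotoxicity, read by MTT assay, with a stated time of 72 h (on this read-out lower numbers stand for stronger inhibition and higher numbers for weaker inhibition), gives 59400 nM.
Compound 2, `Cn1ccc2c(Oc3ccc(NC(=O)c4nn(-c5ccc(Cl)c(F)c5)ccc4=O)cc3)ccnc21`, in this assay gives > 60000 nM, which is a limit of the assay and not a number.

Among the compounds with values here, compound 1 stands as the only real number in this assay; the other result for the series is a limit. Compound 3, `Cn1ccc2c(Oc3ccc(NC(=O)c4nn(-c5ccc(Br)cc5)ccc4=O)cc3F)ccnc21`, differs from compound 1 by fluoro in place of hydrogen on an aromatic carbon. Within the data shown here, only one measured step exists, a number no lower from compound 1 to compound 2 (the limit leaves the size open), and it concerns the group on the aromatic nitrogen, not the ring that carries the new fluoro of compound 3. Its size cannot be read because the value of compound 2 sits at the limit of > 60000 nM in this assay, at which 1 of the 2 values shown sits. Nothing measured therefore speaks directly to the change from compound 1 to compound 3, and the weak inhibition of compound 1 leaves little room for the number to rise before it meets the same limit. The step of a 1.0-fold higher number from compound 1 to compound 3 (0.00 log units; within the scatter) is expected to stay within the usual scatter. Compound 3 is expected to give 60000 nM in this assay, with a range from 25000 nM to 150000 nM, and a good chance that only a limit is reported.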

Compound 3, half-maximal inhibitory concentration: > 60000 nM
Compound 3 gave a limit, no number; the forecaster's own chance of this, stated with the estimate: 55%; the middle value sits exactly at the limit.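

The change at this aromatic carbon gives a number no lower from compound 1 to compound 3 (the limit leaves the size open). Within the data shown here, this is the first result for the ring that carries the fluoro, as the earlier step concerned only the group on the aromatic nitrogen, and it shows that fluoro in place of hydrogen here brings no stronger inhibition in this assay. Among these compounds, the size of this step cannot be read, and with a second change now ending at the same limit, the series offers only one real number: the limit of > 60000 nM in this assay, at which 2 of the 3 values shown sit.

The compounds shown leave open whether fluoro at this position has any effect on the number, since no value for a compound carrying it lies clear of the limit. They also leave open whether an amine or a methoxy group on the same aromatic carbon, or a carboxylic acid on the ring attached to the aromatic nitrogen, would give a real number in this assay.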